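The source may hold more compounds than are shown below. What is called first, only, known or untested is meant among the compounds shown, and "the series" means these compounds.

Of the compounds shown here, three sharing one core have been tested in a functional assay on K562-TAX cells (Homo sapiens), read by MTT assay, with a stated time of 3 days; on this read-out higher numbers stand for weaker inhibition and lower numbers for stronger inhibition. Compound 1 `CN(C)c1ncnc2[nH]cc(Sc3cccs3)c12` gives 22100 nM, compound 2 `Nc1ncnc2[nH]cc(Sc3cccs3)c12` gives 17900 nM, and compound 3 `c1csc(Sc2c[nH]c3ncnc(-c4cccs4)c23)c1` gives 21700 nM. Compound 3 therefore stands level with the other two, and nothing separates the three beyond the scatter of repeated measurements. The next compound, compound 4 `Cc1ncnc2[nH]cc(Sc3cccs3)c12`, has methyl in place of thiophen-2-yl on an aromatic carbon. All three measured steps exchange the group at this same place. They are a 1.2-fold lower number from compound 1 to compound 2 (0.09 log units; within the scatter), a 1.0-fold lower number from compound 1 to compound 3 (0.01 log units; within the scatter) and a 1.2-fold higher number from compound 2 to compound 3 (0.08 log units; within the scatter), and each lies within the scatter. Swapping dimethylamino, amino and thiophen-2-yl has so far left the number unmoved, although methyl itself has not yet been tested here. No shift in either direction beyond the scatter is therefore expected in this assay. The estimated step is a 1.1-fold lower number from compound 3 to compound 4 (0.04 log units; within the scatter). The expected value for compound 4 is 20000 nM, with an estimated range of 11000 nM to 36000 nM.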

Compound 4, half-maximal inhibitory concentration: > 50000 nM
Compound 4: a limit, no number (the forecaster's own chance of this, stated with the estimate: 8%); middle value at least 2.5-fold (0.39 log units) away from the limit.
By their numbers in this assay, from the lowest: compounds 2, 3 and 1 (each within the scatter of the next). At a limit, above all of these: compound 4.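

Methyl at this position, next to the ring nitrogen, is the one exchange shown that moves the result in this assay beyond the scatter: an at least 2.3-fold higher number from compound 3 to compound 4 (0.36 log units; beyond the scatter), an at least 2.7-fold higher number from compound 2 to compound 4 (0.44 log units; beyond the scatter) and an at least 2.2-fold higher number from compound 1 to compound 4 (0.35 log units; beyond the scatter). The position therefore does not accept every group equally, even though dimethylamino, amino and thiophen-2-yl could not be told apart, and among these four groups only methyl is built of carbon alone, although four compounds cannot show that this is what matters. Compound 4 gives a limit rather than a number, so the full size of these steps remains unknown: the limit of > 50000 nM in this assay, at which 1 of the 4 values shown sits.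

Going by these compounds, it remains open whether ethyl or a longer carbon chain would also reach this limit. On these data alone, it also remains open whether a hydroxyl or methoxy group would stay level with compounds 1, 2 and 3.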